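Methoxy to chloro at full plasma recovery

The compounds below may be only part of what the source reports. "The series", "measured", "known", "first", "only" and "open" are said of these compounds alone.

Values in an ADME assay on a cell-free system (plasma, Rattus norvegicus) for metabolic stability, read by LC-MS, with a stated time of 1 h, at 37 degrees C, tested at 100 uM (a higher number here means that more of the compound is left, a lower number that less of the compound is left), so far:
compound 1 `Cn1sc2cc(OCc3cccc(-c4ccc(Cl)c(C(=O)O)c4)c3)ccc2c1=O` gives 100%
compound 2 `O=C(O)c1cc(-c2cccc(COc3ccc4c(=O)n(CC5CC5)sc4c3)c2)ccc1Cl` gives 100%
compound 3 `COc1ccc(C(=O)O)cc1-c1cccc(COc2ccc3c(c2)CN(C2CCCC2)C3=O)c1` gives 100%

Compound 3, at 100%, stands level with compounds 1 and 2, so all three measured compounds share one value. The next compound to be measured is compound 4 `O=C(O)c1ccc(Cl)c(-c2cccc(COc3ccc4c(c3)CN(C3CCCC3)C4=O)c2)c1`, and the change is chloro in place of methoxy on an aromatic carbon. Within the data shown here, no measured step swaps methoxy for chloro. Among the measured compounds shown here, the one measured step, no change at the digits printed from compound 1 to compound 2 (within the scatter), lies elsewhere in the molecule and bears only indirectly. Compound 1 and compound 2 do carry a chloro group, but with another core, and compound 2 gives 100%. For the measured compounds named here, nothing measured so far separates one compound from another, so no direction can be argued from these data. In this assay, the expected step is a number 1 percentage points lower from compound 3 to compound 4 (within the scatter), which means none beyond the scatter. For compound 4 the estimated value is 99%, with an expected range of 90% to 100%.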

Compound 4, percent of the compound remaining: 100%
For compound 4 the middle estimate is 1 percentage points below the measured one; measured number inside the range.
By their numbers in this assay, from the lowest: compounds 1, 2, 3 and 4 (each within the scatter of the next).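

Chloro in place of methoxy, on an aromatic carbon ortho to a large group and para to a carboxy group, gives no change at the digits printed from compound 3 to compound 4 (within the scatter) in this assay. Among these compounds, this is the first measured step at this position, and it shows that the 5-carboxy-2-chlorophenyl group keeps the recovery of the 5-carboxy-2-methoxyphenyl group on the core of compound 3, whereas compounds 1 and 2 carried chloro only on another core. The data on hand give no reason for this result.

All four compounds stand at one level, so nothing yet shows what, if anything, would lower the recovery at this position. From the compounds shown here alone, whether an amine or a longer ether chain there, or a methyl ester in place of the carboxy group, would leave the number unchanged remains open.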